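Swapping one tertiary amide for another on the glycolate side chain

The source may report more compounds than this note shows. Statements on the series, on what has been measured and on what is new or still open speak of the compounds shown alone.

Measured compounds:
- compound 1 `CCOc1cc(NC(=O)C2(NC(=O)c3ccc4c(C5CCCC5)c(-c5ncc(Cl)cn5)n(C)c4c3)CCC2)ccc1/C=C/C(=O)OCC(=O)OC`: 2.08 h
- compound 2 `CCOc1cc(NC(=O)C2(NC(=O)c3ccc4c(C5CCCC5)c(-c5ncc(Cl)cn5)n(C)c4c3)CCC2)ccc1/C=C/C(=O)OCC(=O)N(C)C(C)C`: 0.267 h

Going by the values given here, in an ADME assay (liver) for pharmacokinetics, with Liver microsome (Rattus norvegicus) as the target, using microsomes (a higher number here means that the compound lasts longer, a lower number that the compound disappears faster), compound 2 gives 0.267 h, the lower of the two numbers measured so far; its nearest neighbour is compound 1, whose shared core carries a methoxy on the carbonyl carbon and which gives 2.08 h. Among the compounds with values here, the only measured step, a 7.8-fold lower number from compound 1 to compound 2 (0.89 log units; beyond the scatter), replaces that methoxy with an amine nitrogen. Compound 3 `CCOc1cc(NC(=O)C2(NC(=O)c3ccc4c(C5CCCC5)c(-c5ncc(Cl)cn5)n(C)c4c3)CCC2)ccc1/C=C/C(=O)OCC(=O)N1CCCC1` takes the other direction: pyrrolidin-1-yl in place of isopropyl(methyl)amino on a carbonyl carbon. Within the data shown here, both compound 2 and compound 3 carry a tertiary amide at that carbonyl, so the measured step does not directly cover this change; no step between two amides is available. Compound 3 is therefore expected to stay close to compound 2, with the step of a 1.1-fold higher number from compound 2 to compound 3 (0.05 log units; within the scatter) expected to lie within the scatter. The estimate for compound 3 in this assay is 0.3 h, in a range from 0.1 h to 0.9 h.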

Compound 3, half-life: 1.47 h
Compound 3: middle estimate off by 4.9-fold (0.69 log units), on the low side; measured number outside the range, above it.
By their numbers in this assay, from the lowest: compound 2; then compounds 3 and 1 (each within the scatter of the next).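

In this assay, the two amides at this carbonyl carbon do not behave alike: pyrrolidin-1-yl in place of isopropyl(methyl)amino, with the same count of heavy atoms, gives a 5.5-fold higher number from compound 2 to compound 3 (0.74 log units; beyond the scatter). Replacing methoxy with pyrrolidin-1-yl gives a 1.4-fold lower number from compound 1 to compound 3 (0.15 log units; within the scatter), so an amide nitrogen on this carbonyl carbon does not by itself go with the low number of compound 2, which is tied here to isopropyl(methyl)amino alone. No measurement shown bears on the reason for this gap between the two amides.

The compounds shown leave open whether a larger ring such as piperidin-1-yl or morpholin-4-yl would stay with pyrrolidin-1-yl. They also leave open where a smaller open amine such as dimethylamino would fall.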